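The source may report more compounds than this note shows. Statements on the series, on what has been measured and on what is new or still open speak of the compounds shown alone.

For the measured compounds named here, compound 3 `Cn1c(N2N=C(c3ccccc3)CC2c2ccccc2)nc(-c2ccc(Cl)cc2)c(C#N)c1=O` gives 19500 nM in a functional assay on HT-29 cells (Homo sapiens) for antiproliferative activity, with a stated time of 72 h (on this read-out lower numbers stand for stronger inhibition and higher numbers for weaker inhibition), the highest of the three numbers measured so far. Compound 2 `Cn1c(N2N=C(c3ccccc3)CC2c2ccc(Cl)cc2)nc(-c2ccccc2)c(C#N)c1=O` gives 19200 nM, a value that lies within the scatter of compound 3. Compound 1 `Cn1c(N2N=C(c3ccccc3)CC2c2ccccc2)nc(-c2ccccc2)c(C#N)c1=O` gives 2490 nM, and both the step of a 7.8-fold higher number from compound 1 to compound 3 (0.89 log units; beyond the scatter) and the step of a 7.7-fold higher number from compound 1 to compound 2 (0.89 log units; beyond the scatter) lie beyond the scatter. Compound 4 `Cn1c(N2N=C(c3ccccc3)CC2c2ccc(Cl)cc2)nc(-c2ccc(Cl)cc2)c(C#N)c1=O` differs from compound 3 by chloro in place of hydrogen on an aromatic carbon, a change that reads as phenyl to 4-chlorophenyl when cut one bond further out, sitting on an aromatic carbon of a six-membered aromatic ring of carbon only, para to a large group. The same change, made on compound 1, appears as the step of a 7.7-fold higher number from compound 1 to compound 2 (0.89 log units; beyond the scatter), while the chlorine already present in compound 3 appears as the step of a 7.8-fold higher number from compound 1 to compound 3 (0.89 log units; beyond the scatter). Going by the values given here, both steps were modest and pointed the same way, so a further modest rise in the number is expected for compound 4, although no measured pair shows whether two such changes add up fully. Compound 4 is therefore expected at 100000 nM, within a range from 30000 nM to 300000 nM, which is an expected step of a 5.1-fold higher number from compound 3 to compound 4 (0.71 log units; beyond the scatter) in this assay.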

Compound 4, half-maximal inhibitory concentration: 15000 nM
Beside the measured number, compound 4's estimate is 6.7-fold (0.82 log units) above it; the whole stated range lies above it.
By their numbers in this assay, from the lowest: compound 1; then compounds 4, 2 and 3 (each within the scatter of the next).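

In this assay, the chloro change does not carry the same weight once one 4-chlorophenyl is already in place: phenyl to 4-chlorophenyl now gives a 1.3-fold lower number from compound 3 to compound 4 (0.11 log units; within the scatter), and the gap to the same change on the unchlorinated compound is itself larger than the scatter: the same change on two cores in this assay, a 7.7-fold higher number (0.89 log units; beyond the scatter) from compound 1 to compound 2 and a 1.3-fold lower number (0.11 log units; within the scatter) from compound 3 to compound 4, 10-fold (1.00 log units) apart, beyond the scatter of two such steps The second way through the same four compounds gives the same reading, with a 1.3-fold lower number from compound 2 to compound 4 (0.11 log units; within the scatter), again far from the step seen when the same chlorine is added to compound 1: the same change on two cores in this assay, a 7.8-fold higher number (0.89 log units; beyond the scatter) from compound 1 to compound 3 and a 1.3-fold lower number (0.11 log units; within the scatter) from compound 2 to compound 4, 10-fold (1.00 log units) apart, beyond the scatter of two such steps The two chlorines therefore do not add up in this set: either one alone moves the number beyond the scatter from compound 1, while the second adds nothing that can be told from the scatter, leaving compounds 2, 3 and 4 within the scatter of one another.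

The compounds shown carry only hydrogen or chloro at these places, so it remains open whether a fluoro, a methoxy or an amino group on the same aromatic carbon would behave as chloro does. As far as these compounds go, it is also open whether such a group would show the same lack of addition when paired with a chloro on the other ring.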